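A few compounds are considered here, and "the series" means these few. Any claim that something is new, unique, unknown or untested is made for them only; others in the source may bear on it.

Among the compounds with values here, compound 1 `Nc1ccccc1NC(=O)c1ccc(Cn2cnc3c(Nc4ccccc4)nc(Cl)nc32)cc1` is the strongest of the three compounds measured so far: in a functional assay on NCI-H460 cells (Homo sapiens) for antiproliferative activity, read by CCK-8 assay, with a stated time of 72 h, tested at 8 uM (a higher number here means a stronger effect of the compound at the concentration tested, a lower number a weaker effect), compound 1 gives 77.8%. Compound 3 `CCC(C)n1cnc2c(NCc3ccc(C(=O)Nc4ccccc4N)cc3)nc(Cl)nc21` gives 67.7% in this assay, a number beyond the scatter below it, and compound 2 `CCCCn1cnc2c(Nc3cccc(Cl)c3)nc(NCOCc3ccc(/C=C/C(=O)Nc4ccccc4N)cc3)nc21` gives 51.1%, further below still. Compound 4 `Nc1ccccc1NC(=O)c1ccc(Cn2cnc3c(NCc4ccccc4)nc(Cl)nc32)cc1` has not yet been measured; it differs from compound 1 in one place: benzyl in place of phenyl on a nitrogen on an aromatic ring. Within the data shown here, no measured pair shows this very change, so its size can only be expected, not read off. A small move is expected, if any at all, and the step is estimated as a number 6.8 percentage points lower from compound 1 to compound 4 (within the scatter), slightly downward and hardly beyond the scatter. Compound 4 is therefore expected to give 71%, within 56% and 84%.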

Compound 4, a percentage reported as inhibition, at one concentration (the size of the read-out at that concentration, not a potency): 61.2%
Compound 4: the middle estimate sits 9.8 percentage points above what was measured; the measured number falls inside the stated range.
By their numbers in this assay, from the lowest: compound 2; then compounds 4 and 3 (each within the scatter of the next); then compound 1.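

The step at this position, anilino to benzylamino, reads in this assay as a number 16.6 percentage points lower from compound 1 to compound 4 (beyond the scatter), so the position is not indifferent to this change. Both groups keep the six-membered aromatic ring, so attaching that ring through benzyl rather than directly as phenyl is enough to move the read-out. Nothing available explains why the read-out falls. From the compounds shown here alone, it remains open whether a longer chain such as phenethyl, or a plain methyl, on this nitrogen would continue the same direction. This single pair also cannot show whether the step holds on other side chains of the shared core.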